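From Methyl to Sulfamoyl: Expecting the Potency of Compound 4

The compounds below may be only part of what the source reports. "The series", "measured", "known", "first", "only" and "open" are said of these compounds alone.

Of the compounds shown here, three built on one shared core have been tested in a functional assay on HEK293 cells for antagonist activity at transient receptor potential cation channel subfamily V member 1 (Rattus norvegicus), read by calcium flux; on this read-out lower numbers stand for stronger inhibition and higher numbers for weaker inhibition. Compound 1 `FC(F)(F)c1ccc(Nc2ncnc3sc(Nc4ccccc4Cl)nc23)cc1` gives 32 nM. Compound 2 `FC(F)(F)c1ccc(Nc2ncnc3sc(Nc4ccccc4C(F)(F)F)nc23)cc1` gives 37 nM. The step of a 1.2-fold higher number from compound 1 to compound 2 (0.06 log units; within the scatter) lies within the scatter. Compound 3 `Cc1ccc(Nc2ncnc3sc(Nc4c(Cl)cccc4Cl)nc23)cc1` gives 32 nM, level with compound 1 at the digits shown and, together with it, the lowest of the three numbers; its gap to compound 2 is also within the scatter.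

Compound 4 `NS(=O)(=O)c1ccc(Nc2ncnc3sc(Nc4c(Cl)cccc4Cl)nc23)cc1` has not yet been measured. It differs from compound 3 by sulfamoyl in place of methyl on an aromatic carbon. Among the measured compounds shown here, no measured step touches this place: the only step available changes a group on the other aromatic ring and stayed within the scatter, so it says nothing about exchanging methyl for sulfamoyl. The expectation therefore rests only on the observation that the varied groups on the two outer rings of compound 1, compound 2 and compound 3 all gave numbers close together, which makes a very large move seem less likely without ruling it out. Compound 4 is expected to give about 80 nM, with a likely range from 20 nM to 400 nM. That estimate means an expected step of a 2.5-fold higher number from compound 3 to compound 4 (0.40 log units; beyond the scatter), a modest weakening that is not far outside the usual scatter.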

Compound 4, half-maximal inhibitory concentration: 590 nM
The estimate for compound 4 lay 7.4-fold (0.87 log units) below the measured number; the measured number lies above the stated range.
By their numbers in this assay, from the lowest: compounds 1, 3 and 2 (each within the scatter of the next); then compound 4.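

In this assay, sulfamoyl in place of methyl on the aromatic carbon para to a large group gives an 18-fold higher number from compound 3 to compound 4 (1.27 log units; beyond the scatter), a large weakening of inhibition, so the number can depend strongly on what sits at this place. Among the compounds shown here, the only earlier step, a 1.2-fold higher number from compound 1 to compound 2 (0.06 log units; within the scatter), changed a group on the other aromatic ring and stayed within the scatter, which gave no sign that a single exchange could move the number this far. The exchange swaps one heavy atom for four and brings in a hydrogen-bond donor and two hydrogen-bond acceptors, yet no measurement here separates these changes or explains the weaker inhibition.

With the rest of compound 3 held fixed, only methyl and sulfamoyl can be compared at this place, so the compounds shown leave open how an amine, a carboxylic acid, a methylsulfonyl group or a longer chain would behave there. For the compounds shown here, they also leave open whether the same exchange would cost as much alongside a different group on the other aromatic ring, such as the one in compound 1.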